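The source may hold more compounds than are shown below. What is called first, only, known or untested is meant among the compounds shown, and "the series" means these compounds.

In a functional assay on MCF7 cells (Homo sapiens) for cytotoxicity, read by MTT assay, with a stated time of 96 h (on this read-out lower numbers stand for stronger inhibition and higher numbers for weaker inhibition), three compounds sharing one core have been measured. Compound 1 `COc1cc(C(=O)c2cn(-c3ccccc3Cl)cc2-c2ccccc2)cc(OC)c1OC` gives 1800 nM, compound 2 `COc1cc(C(=O)c2cn(-c3ccccc3[N+](=O)[O-])cc2-c2ccccc2)cc(OC)c1OC` gives 5000 nM, and compound 3 `COc1cc(C(=O)c2cn(-c3cccc(Br)c3)cc2-c2ccccc2)cc(OC)c1OC` gives 78 nM, the lowest number of the three. Compound 4 `COc1cccc(-n2cc(C(=O)c3cc(OC)c(OC)c(OC)c3)c(-c3ccccc3)c2)c1` has not yet been measured. It differs from compound 3 by a single exchange, methoxy in place of bromo on an aromatic carbon, meta to a large group: methoxy in place of bromo on an aromatic carbon.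

Among the compounds with values here, no measured step makes this exact exchange. The closest is a 2.8-fold higher number from compound 1 to compound 2 (0.44 log units; beyond the scatter), where nitro replaces chloro on an aromatic carbon, and that step is modest. The steps of a 23-fold lower number from compound 1 to compound 3 (1.36 log units; beyond the scatter) and a 64-fold lower number from compound 2 to compound 3 (1.81 log units; beyond the scatter) are both large, but each replaces 2-chlorophenyl or 2-nitrophenyl with 3-bromophenyl. Neither therefore carries over directly to the change from 3-bromophenyl to 3-methoxyphenyl. Within the data shown here, with only one substituent exchanged, a modest step is more likely than a large one, and a higher number is the likelier direction, since compound 3 holds the lowest value so far. In this assay, the expected change is a 2.2-fold higher number from compound 3 to compound 4 (0.34 log units; beyond the scatter). For compound 4, the estimated value is 170 nM, with an expected range from 45 nM to 650 nM.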

Compound 4, half-maximal inhibitory concentration: 500 nM
The estimate for compound 4 lay 2.9-fold (0.47 log units) below the measured number; measured number inside the range.
By their numbers in this assay, from the lowest: compound 3; then compound 4; then compound 1; then compound 2.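

Within the data shown here, with the place on the ring held fixed, the exchange of bromo for methoxy alone gives a 6.4-fold higher number from compound 3 to compound 4 (0.81 log units; beyond the scatter) in this assay, so the group on this aromatic carbon matters in its own right, something the earlier steps could not show, as each of them changed the group and its place together. The 3-methoxyphenyl group still keeps much of the gain seen with 3-bromophenyl, with a 10-fold lower number from compound 2 to compound 4 (1.00 log units; beyond the scatter) and a 3.6-fold lower number from compound 1 to compound 4 (0.56 log units; beyond the scatter), and among these four compounds both 3-substituted phenyl groups give lower numbers than both 2-substituted ones, with no compound going against that order. No measurement at hand offers an explanation for the rise on going from bromo to methoxy.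

The compounds shown leave open how far the number depends on the place of the substituent rather than its identity, since no single group appears here at both places, as a pair such as 2-methoxyphenyl and 3-methoxyphenyl would allow. They also leave open what an amine, a hydroxy group or a longer chain such as ethoxy would give on this same aromatic carbon, and how a plain phenyl group on the aromatic nitrogen compares.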